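The source may report more compounds than this note shows. Statements on the series, on what has been measured and on what is new or still open speak of the compounds shown alone.

Compound 1 `CCOc1cccnc1Nc1cccc(C)n1` and compound 2 `CCCOc1cccnc1Nc1cccc(C)n1` share one core and differ only on the alkoxy chain. In an assay on Ltk cells with metabotropic glutamate receptor 5 (Homo sapiens) as the target, read by fluorescence and calcium flux (a higher number here means a weaker inhibitor, a lower number a stronger inhibitor), compound 1 gives 40 nM, and compound 2 gives 1600 nM. Going by the values given here, the single step between them, a 40-fold higher number from compound 1 to compound 2 (1.60 log units; beyond the scatter), arose from a methyl in place of hydrogen on a saturated chain carbon, two bonds along the chain from an oxygen on an aromatic ring. Compound 1 therefore stands lowest of the two numbers seen so far.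

Compound 3 `CCOc1cc(-c2cccnc2C#N)cnc1Nc1cccc(C)n1` keeps the ethoxy group of compound 1 unchanged and instead carries 2-cyanopyridin-3-yl in place of hydrogen on an aromatic carbon, on an aromatic carbon of the core, two atoms from the ring nitrogen. Among the compounds with values here, no measured step touches that part of the core, so the step from compound 1 to compound 2 gives no direct guide, and the size and direction of the change are uncertain. Compound 3 is estimated at 20 nM (range 3 nM to 150 nM), a step of a 2.0-fold lower number from compound 1 to compound 3 (0.30 log units; within the scatter) expected to stay near the scatter.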

Compound 3, half-maximal inhibitory concentration: 80 nM
The estimate for compound 3 lay 4.0-fold (0.60 log units) below the measured number; the range from low to high includes it.
By their numbers in this assay, from the lowest: compounds 1 and 3 (each within the scatter of the next); then compound 2.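

In this assay, the result a 2.0-fold higher number from compound 1 to compound 3 (0.30 log units; within the scatter) shows that this aromatic carbon, two atoms from the ring nitrogen, can carry a 2-cyanopyridin-3-yl group of 8 heavy atoms in place of hydrogen without a step beyond the scatter. The earlier compounds shown here showed only that the alkoxy chain is sensitive, with a single added methyl giving a 40-fold higher number from compound 1 to compound 2 (1.60 log units; beyond the scatter), whereas this much bigger addition at the new position leaves compound 3 indistinguishable from its parent in this measurement. Nothing available explains why the two places differ so much.

Going by these compounds, it remains open what a plain phenyl ring, a morpholine or a pyridin-3-yl group without the nitrile would give at this carbon. On these data alone, it is also open whether the 2-cyanopyridin-3-yl group would give a similar result on the longer chain of compound 2.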